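A few compounds are considered here, and "the series" means these few. Any claim that something is new, unique, unknown or untested is made for them only; others in the source may bear on it.

Compound 2 `Cc1ccccc1CN1CCC(NC(=O)c2cccc3ccccc23)CC1` is one of two compounds tested in an assay on isolated protein for displacement of a labelled ligand from D(4) dopamine receptor (Homo sapiens); on this read-out lower numbers stand for stronger inhibition and higher numbers for weaker inhibition. Compound 2 gives 155 nM, the higher of the two numbers, while compound 1 `O=C(NC1CCN(Cc2cccc(Br)c2)CC1)c1cccc2ccccc12` gives 66 nM. Among the measured compounds shown here, the only step measured so far is a 2.3-fold higher number from compound 1 to compound 2 (0.37 log units; beyond the scatter), and it concerns the same place as the change now at hand. Compound 3 `Cc1cccc(CN2CCC(NC(=O)c3cccc4ccccc34)CC2)c1` differs from compound 2 by 3-methylphenyl in place of 2-methylphenyl on a saturated chain carbon bound to an amine nitrogen in a ring. For the measured compounds named here, compound 1 carries a 3-bromophenyl at this position and compound 3 a 3-methylphenyl, so compound 1 is the nearer reference, but no measured step links a 2-methylphenyl directly to a 3-methylphenyl here. The expected step is therefore a modest move toward the number of compound 1, roughly a 1.6-fold lower number from compound 2 to compound 3 (0.21 log units; within the scatter) in this assay. Compound 3 is estimated at 95 nM, with a range from 40 nM to 220 nM.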

Compound 3, inhibition constant: 77 nM
Beside the measured number, compound 3's estimate is 1.2-fold (0.09 log units) above it; measured number inside the range.
By their numbers in this assay, from the lowest: compounds 1, 3 and 2 (each within the scatter of the next, the first and the last beyond it).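

Moving the methyl group alone, with the same atoms joined differently, gives a 2.0-fold lower number from compound 2 to compound 3 (0.30 log units; within the scatter) in this assay, so 2-methylphenyl and 3-methylphenyl cannot be told apart at this position. Methyl in place of bromo on an aromatic carbon gives a 1.2-fold higher number from compound 1 to compound 3 (0.07 log units; within the scatter), so that exchange cannot be distinguished in this series either. Compound 3 thus sits within the scatter of both neighbours, while a 2.3-fold higher number from compound 1 to compound 2 (0.37 log units; beyond the scatter) remains beyond it, and that earlier step, which changed both the substituent and its place, cannot be assigned to either change alone. As far as these compounds go, it remains open whether a methoxy group or an amine in place of the methyl would give a clearly different number in this assay on this core. Nothing available explains why these numbers fall as they do.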